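The compounds below may be only part of what the source reports. "The series", "measured", "known", "first", "only" and "open" are said of these compounds alone.

Measured so far:
compound 1 `Fc1cc2nc(-c3cccnc3)n(C3CC3)c2cc1F` — 370 nM
compound 2 `N#Cc1cc2c(cc1F)nc(-c1cncc(F)c1)n2C1CC1` — 225 nM

In an assay on V79 cells for inhibition of cytochrome P450 11B1, mitochondrial (Homo sapiens), read by HTRF, with a stated time of 1 h (a lower number here means a stronger inhibitor, a higher number a weaker inhibitor), compound 1 gives 370 nM, and compound 2 gives 225 nM. Compound 2 holds the lowest of the two numbers, but its nearest neighbour, compound 1, lies within the scatter of repeated measurements, so the two read as equivalent on this assay.

Compound 3 `N#Cc1cc2c(cc1F)nc(-c1cccnc1)n2C1CC1` is not yet measured. It differs from compound 2 in one place: hydrogen in place of fluoro on an aromatic carbon — hydrogen in place of fluoro on an aromatic carbon, two atoms from the ring nitrogen, meta to a large group. Among the compounds with values here, no step between measured compounds isolates this change, and the two measured values sit within the scatter of each other, so nothing in the data points to a direction.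

For compound 3 the expectation is therefore a step of a 1.3-fold higher number from compound 2 to compound 3 (0.12 log units; within the scatter), not beyond the scatter. Compound 3 is estimated at 300 nM, with a range from 130 nM to 700 nM.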

Compound 3, half-maximal inhibitory concentration: 117 nM
Compound 3: the middle estimate sits 2.6-fold (0.41 log units) above what was measured; the whole stated range lies above it.
By their numbers in this assay, from the lowest: compounds 3, 2 and 1 (each within the scatter of the next, the first and the last beyond it).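

In this assay, within the data shown here, the 5-fluoropyridin-3-yl to pyridin-3-yl change gives the first isolated reading at this position, two atoms from the ring nitrogen: a 1.9-fold lower number from compound 2 to compound 3 (0.28 log units; within the scatter), so the two groups cannot be told apart here. Cyano in place of fluoro on an aromatic carbon of the shared core gives a 3.2-fold lower number from compound 1 to compound 3 (0.50 log units; beyond the scatter), a modest step but the only one of these two beyond the scatter, and it is read with pyridin-3-yl alone. No supporting measurement explains either step.

Going by these compounds, compound 1 and compound 2 differ in more than one place, so whether the cyano step holds with 5-fluoropyridin-3-yl remains open. Also open, on these data alone, is how an amine or a methoxy group would read at this same position on the ring.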